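Compound 2 Gives Up Its Methoxy Group

This account rests on a few compounds, and the source may have more. Where it says the series, first, only, none or still open, it means among the compounds named here.

Compound 1 (`O=c1cc(NC2CCCCC2)cc(/C=C/c2ccccc2)o1`) with 1.24 uM
Compound 2 (`COc1cccc(Nc2cc(-c3ccccc3)oc(=O)c2)c1`) with 0.55 uM

Both compounds were tested in a functional assay on KBVIN cells (Homo sapiens) for cytotoxicity, read by MTT assay, with a stated time of 72 h; a higher number here means that more compound is needed for the effect, a lower number that less compound is needed. Compound 2 gives the lower of the two numbers at 0.55 uM and its gap to compound 1 at 1.24 uM lies beyond the usual scatter. The next compound, compound 3 (`O=c1cc(Nc2ccccc2)cc(-c2ccccc2)o1`), has hydrogen in place of methoxy on an aromatic carbon. For the measured compounds named here, no measured pair shows what this exchange does, so any forecast for this assay remains uncertain. A modest shift towards a higher number is expected, but nothing beyond the scatter. The estimated change is a 1.5-fold higher number from compound 2 to compound 3 (0.16 log units; within the scatter) and so stays small. Compound 3 is expected at 0.8 uM within an estimated range from 0.3 uM to 2.5 uM as its measurement in this assay is awaited.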

Compound 3, concentration for half-maximal effect: 0.15 uM
Beside the measured number, compound 3's estimate is 5.3-fold (0.73 log units) above it; the whole stated range lies above it.
By their numbers in this assay, from the lowest: compound 3; then compound 2; then compound 1.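

In this assay the exchange of methoxy for hydrogen gives a 3.7-fold lower number from compound 2 to compound 3 (0.56 log units; beyond the scatter), so on this aromatic carbon, meta to a large group, the methoxy group is not needed for a low number, and the compound without it needs less compound for the effect. For the compounds shown here, this is the first reading of this position, since compound 1 differs from the other two compounds in more than one place and could say nothing about it. No measurement at hand gives a reason for this step.

From the compounds shown here alone, whether a fluorine atom, a hydroxyl group or an amine at this carbon would lower the number further or raise it again remains open. Also open, going by these compounds, is whether methoxy on another carbon of the same ring would follow the same course.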